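The source may report more compounds than this note shows. Statements on the series, on what has been measured and on what is new or still open speak of the compounds shown alone.

In a functional assay on MOLT-4 cells (Homo sapiens) for cytotoxicity, read by sulforhodamine B assay, with a stated time of 48 h, tested at 1 uM (on this read-out lower numbers stand for a stronger effect and higher numbers for a weaker effect at the one concentration tested), compound 2 `COc1ccc(C(=O)/C=C/c2cc(-c3cc(OC)c(OC)c(OC)c3)n[nH]2)cc1OC` gives 88%. Among the compounds with values here, of the three numbers measured so far this sits among the higher ones: compound 3 `COc1cc(-c2cc(/C=C/C(=O)c3ccc(F)c(F)c3)[nH]n2)cc(OC)c1OC` gives 91%, a value within the scatter of that of compound 2, while compound 1 `COc1cc(-c2cc(/C=C/C(=O)c3ccc(N)cc3)[nH]n2)cc(OC)c1OC` gives 72%, a value lower beyond the scatter. The steps of a number 16 percentage points higher from compound 1 to compound 2 (beyond the scatter) and a number 19 percentage points higher from compound 1 to compound 3 (beyond the scatter) were both beyond the scatter, whereas the step of a number 3 percentage points higher from compound 2 to compound 3 (within the scatter) stayed within it.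

Compound 4 `COc1cc(C(=O)/C=C/c2cc(-c3cc(OC)c(OC)c(OC)c3)n[nH]2)cc(OC)c1OC` differs from compound 2 in one place: methoxy in place of hydrogen on an aromatic carbon. Within the data shown here, none of the measured steps adds a group in this way; each of them exchanges the whole aryl group on the carbonyl carbon. The closest guide is the step of a number 3 percentage points higher from compound 2 to compound 3 (within the scatter), which remained within the scatter even though that aryl group was replaced entirely. The step of a number 2 percentage points lower from compound 2 to compound 4 (within the scatter) is therefore expected to be small, most likely within the scatter, in no particular direction. In this assay compound 4 is estimated at 86%, with a range from 72% to 100%.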

Compound 4, a percentage reported as activity, at one concentration (the size of the read-out at that concentration, not a potency): 81%
Compound 4: middle estimate off by 5 percentage points, on the high side; low and high end bracket the measured number.
By their numbers in this assay, from the lowest: compounds 1, 4, 2 and 3 (each within the scatter of the next, the first and the last beyond it).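

Within the data shown here, compound 4 gives the first case in this set of a group added to the aryl ring on the carbonyl carbon, where the earlier steps each exchanged that whole aryl group. In this assay, the step of a number 7 percentage points lower from compound 2 to compound 4 (within the scatter) shows that methoxy in place of hydrogen, ortho to a methoxy group and meta to a large group, stays within the usual scatter of this read-out at the one concentration tested, so this position accepts the added methoxy without a clear shift in the number. Nothing available explains this result or links it to any measured property of the group.

The compounds shown leave open whether a hydroxyl, an ethoxy or a carboxylic acid at this same position would also stay this close to compound 2. They also leave open whether the step would remain this small with an amine on the ring in place of the methoxy groups.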